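Thiosemicarbazone series: swapping the chlorobenzylidene for a phenylethylidene

The compounds below may be only part of what the source reports. "The series", "measured", "known", "first", "only" and "open" are said of these compounds alone.

The series shares one core, seen in compound 1 `CC1=CC[C@@H]([C@@](C)(O)CCCC(C)(C)NC(=S)NN)CC1`. In a functional assay on HT-29 cells (Homo sapiens) for cytotoxicity, read by sulforhodamine B assay (a lower number here means that less compound is tolerated, a higher number that more compound is tolerated), compound 1 gives > 100000 nM, a limit of the assay and not a number. Compound 2 `CC1=CC[C@@H]([C@@](C)(O)CCCC(C)(C)NC(=S)N/N=C\c2ccccc2)CC1` gives 57400 nM in this assay. Compound 3 `CC1=CC[C@@H]([C@@](C)(O)CCCC(C)(C)NC(=S)N/N=C\c2ccccc2Cl)CC1` gives > 100000 nM, again a limit of the assay. Compound 3 therefore sits at the same limit as compound 1 (the limit of > 100000 nM in this assay, at which 2 of the 3 values shown sit), and no number is known for it. The step of an at least 1.7-fold higher number from compound 2 to compound 3 (0.24 log units; that floor lies within the scatter) shows only that the chloro did not lower the number.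

Compound 4 `CC1=CC[C@@H]([C@@](C)(O)CCCC(C)(C)NC(=S)N/N=C(/C)c2ccccc2)CC1` differs from compound 3 by a group of 9 heavy atoms (8 carbon, 1 nitrogen; one six-membered aromatic ring of carbon only) in place of a group of 9 heavy atoms (7 carbon, 1 nitrogen, 1 chlorine; one six-membered aromatic ring of carbon only), on an amide-type nitrogen: the chlorine is gone and a methyl has been added on the double bond. Compound 4 thus stands nearer to compound 2 than to compound 3. Among the compounds with values here, the only step that bears on it, an at least 1.7-fold higher number from compound 2 to compound 3 (0.24 log units; that floor lies within the scatter), has a floor within the scatter, so no step beyond the scatter is expected in this assay in either direction. Compound 4 is expected to give about 60000 nM, between 25000 nM and 150000 nM. That estimate amounts to a step of an at least 1.6-fold lower number from compound 3 to compound 4 (0.22 log units; that floor lies within the scatter), read against a limit.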

Compound 4, concentration lethal to 50% of the cells: > 100000 nM
Compound 4: no number, only a limit (the forecaster's own chance of this, stated with the estimate: 40%); middle value at least 1.6-fold (0.22 log units) away from the limit.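

In this assay the methyl added on the double bond gives an at least 1.7-fold higher number from compound 2 to compound 4 (0.24 log units; that floor lies within the scatter) and so, like the chloro, did not lower the number, though that floor lies within the scatter. Compound 4 gives > 100000 nM as a limit of the assay and not a number. The steps from compound 1 and from compound 3 to compound 4 cannot be read, and the series now gathers at a single limit: the limit of > 100000 nM in this assay, at which 3 of the 4 values shown sit.

Within the data shown here, compound 2 remains the only compound here with a number, so it stays open how far any change on this amide-type nitrogen can bring the number down. Whether an amine or a carboxylic acid in place of the chlorine, or an ethyl in place of the added methyl, would give a number under the limit is not settled by these compounds.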